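This account rests on a few compounds, and the source may have more. Where it says the series, first, only, none or still open, it means among the compounds named here.

Compound 1 `Nc1nc(Cl)c2ncn(Cc3ccc(CCl)cc3)c2n1`: in a functional assay on T47D cells (Homo sapiens) for cytotoxicity, read by sulforhodamine B assay, with a stated time of 48 h (a lower number here means that less compound is tolerated, a higher number that more compound is tolerated), compound 1 gives > 100000 nM, a limit of the assay.
Compound 2 `ClCc1cccc(Cn2cnc3c(Cl)nc(Cl)nc32)c1`: compound 2 gives > 100000 nM, also a limit.
Compound 3 `ClCc1ccc(Cn2cnc3c(Cl)nc(Cl)nc32)cc1`: compound 3 gives > 100000 nM, again a limit.

The change from compound 3 to compound 1 is amino in place of chloro on an aromatic carbon. Its step that the two limits leave unreadable from compound 3 to compound 1 cannot be read because the limit of > 100000 nM in this assay, at which 3 of the 3 values shown sit, is where both values sit. Compound 2 and compound 3 contain the same atoms joined differently; the difference between the two cores is not broken down here. Compound 4 `Nc1nc(Cl)c2ncn(Cc3cccc(CCl)c3)c2n1` arises from compound 2 by amino in place of chloro on an aromatic carbon, the same change as before, since the surroundings of the place match word for word. The expectation rests on compound 1, which in this assay gave only a limit, > 100000 nM. Compound 4 is therefore expected to show a step that the limit leaves unreadable from compound 2 to compound 4 and a value near 150000 nM, estimated between 60000 nM and 400000 nM, most probably reported again as a limit.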

Compound 4, concentration lethal to 50% of the cells: > 100000 nM
Compound 4: no number, only a limit (the forecaster's own chance of this, stated with the estimate: 85%); the middle value does not contradict the limit.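

The step from compound 2 to compound 4 cannot be read, because both values are limits and not numbers: the limit of > 100000 nM in this assay, at which 4 of the 4 values shown sit.

The compounds shown leave open whether amino in place of chloro changes the result in this assay at all.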